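Phenylsulfonyl in place of an aryloxy linker on the shared core

The source may report more compounds than this note shows. Statements on the series, on what has been measured and on what is new or still open speak of the compounds shown alone.

Measured compounds in an assay for inhibition of Thromboxane-A synthase (Homo sapiens), using microsomes; a higher number here means a weaker inhibitor, a lower number a stronger inhibitor:
compound 1 `CC(C)(Oc1ccc(F)cc1)C1OCC(C/C=C\CCC(=O)O)C(c2cccnc2)O1`: 51 nM
compound 2 `CSc1ccccc1OC(C)(C)C1OCC(C/C=C\CCC(=O)O)C(c2cccnc2)O1`: 36 nM
compound 3 `COc1ccc(OC(C)(C)C2OCC(C/C=C\CCC(=O)O)C(c3cccnc3)O2)c([N+](=O)[O-])c1`: 37 nM

The three numbers cannot be told apart: a 1.4-fold lower number from compound 1 to compound 2 (0.15 log units; within the scatter), a 1.4-fold lower number from compound 1 to compound 3 (0.14 log units; within the scatter) and a 1.0-fold higher number from compound 2 to compound 3 (0.01 log units; within the scatter) all lie within the scatter, so compound 2 stands level with the others in this assay. Compound 4 `CC(C)(C1OCC(C/C=C\CCC(=O)O)C(c2cccnc2)O1)S(=O)(=O)c1ccccc1` differs from compound 2 by phenylsulfonyl in place of 2-(methylsulfanyl)phenoxy on a saturated chain carbon bound to two saturated chain carbons and a saturated ring carbon. Every measured step changes only the substituents on the aryl ring while keeping the oxygen link; none of them bears on replacing that oxygen with a sulfonyl, and none moved the number beyond the scatter. The step of a 1.7-fold higher number from compound 2 to compound 4 (0.22 log units; within the scatter) is therefore expected to be small in either direction, with wide uncertainty. For compound 4 the estimate in this assay is 60 nM, between 15 nM and 250 nM.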

Compound 4, half-maximal inhibitory concentration: 40 nM
Compound 4: the middle estimate sits 1.5-fold (0.18 log units) above what was measured, within the range that was stated.
By their numbers in this assay, from the lowest: compounds 2, 3, 4 and 1 (each within the scatter of the next).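

Earlier steps changed only the aryl ring on the oxygen link, whereas this change replaces the link itself on the saturated chain carbon. In this assay the replacement leaves the compounds level, with a 1.1-fold higher number from compound 2 to compound 4 (0.05 log units; within the scatter) and a 1.3-fold lower number from compound 1 to compound 4 (0.11 log units; within the scatter), so at this place phenylsulfonyl cannot be told apart from 2-(methylsulfanyl)phenoxy or 4-fluorophenoxy. Nothing available explains this result. Going by these compounds, it remains open whether the same holds for a 4-fluorophenylsulfonyl group, or for an amine linking the aromatic ring to this carbon.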